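Amino on the Core: Notes on a Nucleoside Series

This account rests on a few compounds, and the source may have more. Where it says the series, first, only, none or still open, it means among the compounds named here.

Compound 1 `COc1ncnc2c1c(-c1cccs1)cn2[C@@H]1O[C@H](CO)[C@@H](O)[C@H]1O` and compound 2 `COc1nc(N)nc2c1c(-c1cccs1)cn2[C@@H]1O[C@H](CO)[C@@H](O)[C@H]1O` share one core; compound 2 carries amino in place of hydrogen on an aromatic carbon. In an ADME assay on BJ cells (Homo sapiens), read by MTT assay, with a stated time of 72 h (on this read-out higher numbers stand for weaker inhibition and lower numbers for stronger inhibition), compound 1 gives 62800 nM. In this assay compound 2 gives 99900 nM. The step is a 1.6-fold higher number from compound 1 to compound 2 (0.20 log units; within the scatter).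

Compound 3 `O=c1[nH]cnc2c1c(-c1ccco1)cn2[C@@H]1O[C@H](CO)[C@@H](O)[C@H]1O` has another core; the difference between the two cores is not broken down here. In this assay compound 3 reaches only a limit, > 100000 nM. This value sits at the limit of > 100000 nM in this assay, at which 1 of the 3 values shown sits.

Compound 4 `Nc1nc2c(c(-c3ccco3)cn2[C@@H]2O[C@H](CO)[C@@H](O)[C@H]2O)c(=O)[nH]1` is compound 3 with amino in place of hydrogen on an aromatic carbon. This is the same kind of change as in compound 2, though the place is not identical: in compound 2 it is meta to a methoxy group (2 heavy atoms), in compound 4 meta to a group of 1 heavy atom. The expected step is a step that the limit leaves unreadable from compound 3 to compound 4, resting on the measured 1.6-fold higher number from compound 1 to compound 2 (0.20 log units; within the scatter). Compound 4 is therefore expected at 150000 nM, within 70000 nM to 400000 nM, most likely again as a limit.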

Compound 4, half-maximal inhibitory concentration: > 100000 nM
Compound 4: a limit, no number; the forecaster's own chance of this, stated with the estimate: 80%; the middle value is on the limit's open side.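

Compound 3 and compound 4 both stand as limits, so no step between them can be read: the limit of > 100000 nM in this assay, at which 2 of the 4 values shown sit.

The compounds shown leave open how amino in place of hydrogen on an aromatic carbon shifts the value on the core of compound 3.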